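From 3-methylphenyl to 3,4-dimethoxyphenyl

The source may hold more compounds than are shown below. What is called first, only, known or untested is meant among the compounds shown, and "the series" means these compounds.

Measured in a functional assay on A2780 cells (Homo sapiens) for antiproliferative activity, read by MTT assay, with a stated time of 48 h; on this read-out higher numbers stand for weaker inhibition of growth and lower numbers for stronger inhibition of growth:
compound 1 `COC(=O)N1N=C(c2cccc(OC)c2)CC1c1cc(OC)c(OC)c(OC)c1`: 2780 nM
compound 2 `COC(=O)N1N=C(c2cccc(O)c2)CC1c1cc(OC)c(OC)c(OC)c1`: 810 nM
compound 3 `COC(=O)N1N=C(c2cccc(C)c2)CC1c1cc(OC)c(OC)c(OC)c1`: 600 nM

Compound 3 stands at the low end of these numbers, level within the scatter with its nearest neighbour (a 1.4-fold lower number from compound 2 to compound 3 (0.13 log units; within the scatter)). Compound 4 `COC(=O)N1N=C(c2ccc(OC)c(OC)c2)CC1c1cc(OC)c(OC)c(OC)c1` carries 3,4-dimethoxyphenyl in place of 3-methylphenyl on a carbon with a double bond to nitrogen and so brings methoxy back. The closest guide is the modest step with methyl in place of methoxy (a 4.6-fold lower number from compound 1 to compound 3 (0.67 log units; beyond the scatter)), and removing the methyl from that oxygen gave a similar step (a 3.4-fold lower number from compound 1 to compound 2 (0.54 log units; beyond the scatter)). Within the data shown here, the second methoxy has no measured precedent. A modest step to a higher number is therefore expected in this assay, and this estimated step is a 4.2-fold higher number from compound 3 to compound 4 (0.62 log units; beyond the scatter) in size. Compound 4 is expected at about 2500 nM, with an estimated range of 800 nM to 7500 nM for this value.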

Compound 4, concentration for 50% growth inhibition: 11400 nM
The estimate for compound 4 lay 4.6-fold (0.66 log units) below the measured number; the measured number lies above the stated range.
By their numbers in this assay, from the lowest: compounds 3 and 2 (each within the scatter of the next); then compound 1; then compound 4.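

In this assay, among these compounds, the second methoxy has a measured cost of its own (a 4.1-fold higher number from compound 1 to compound 4 (0.61 log units; beyond the scatter)), which the earlier compounds could not show. Against the other two rings the change is larger (a 19-fold higher number from compound 3 to compound 4 (1.28 log units; beyond the scatter); a 14-fold higher number from compound 2 to compound 4 (1.15 log units; beyond the scatter)), so 3,4-dimethoxyphenyl gives the weakest growth inhibition of the four compounds at this ring carbon. No supporting measurement is available to explain this loss.

The compounds shown leave open how an amine or a carboxylic acid on this aromatic ring would behave. They also leave open whether 3,4-dimethylphenyl would carry a similar cost.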